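The source may report more compounds than this note shows. Statements on the series, on what has been measured and on what is new or still open speak of the compounds shown alone.

In a functional assay on HT-29 cells (Homo sapiens) for antiproliferative activity, read by sulforhodamine B assay, with a stated time of 72 h (a lower number here means a stronger inhibitor, a higher number a weaker inhibitor), the values so far are these:

Compound 1 `FC(F)(F)c1ccccc1NC(=S)N/N=C/c1ccc2ccccc2n1` gives 18100 nM
Compound 2 `Fc1ccc(NC(=S)N/N=C/c2ccc3ccccc3n2)cc1` gives 28500 nM

Among the measured compounds shown here, only these two compounds have numbers so far. Compound 2 at 28500 nM lies within the usual scatter of compound 1 at 18100 nM in this series, so the two cannot be told apart.

Compound 3 `S=C(N/N=C/c1ccc2ccccc2n1)Nc1ccccc1` has not yet been measured. It keeps the shared core of compound 2 and carries hydrogen in place of fluoro on an aromatic carbon, para to a large group (hydrogen in place of fluoro on an aromatic carbon), so that 4-fluorophenyl becomes phenyl. For the measured compounds named here, no measured step for this change is available, and the expectation therefore rests on the two values alone. In this assay no step beyond the scatter is expected in either direction, and compound 3 is expected to stay close to compound 2 at 28500 nM in the measured range. The expected change is small, a 1.1-fold lower number from compound 2 to compound 3 (0.06 log units; within the scatter) as estimated. For compound 3 the estimate is 25000 nM with an expected range from 9000 nM to 60000 nM for the measurement.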

Compound 3, half-maximal inhibitory concentration: 17000 nM
Estimate against measurement, compound 3: 1.5-fold (0.17 log units) above; measured number inside the range.
By their numbers in this assay, from the lowest: compounds 3, 1 and 2 (each within the scatter of the next).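

With the unsubstituted phenyl compound in hand, this assay now gives a direct reading of fluoro on an aromatic carbon, para to a large group: exchanging it for hydrogen gives a 1.7-fold lower number from compound 2 to compound 3 (0.22 log units; within the scatter). The exchange of trifluoromethyl for hydrogen on an aromatic carbon gives a 1.1-fold lower number from compound 1 to compound 3 (0.03 log units; within the scatter), so neither substituent can be distinguished from hydrogen in this assay. No further measurement is available that bears on these results.

It remains open whether any group at this place on the phenyl ring, such as a methoxy group, an amine or a carboxylic acid, would produce a step beyond the scatter, since all three compounds shown carry only hydrogen, fluoro or trifluoromethyl. Among the compounds shown here, it is also open whether the thiocarbonyl of the shared core matters, as no compound here carries a carbonyl in its place.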